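Replacing 4-methylphenoxy with propyl in compound 3

The source may report more compounds than this note shows. Statements on the series, on what has been measured and on what is new or still open speak of the compounds shown alone.

In a functional assay on HCT-116 cells (Homo sapiens) for antiproliferative activity, read by MTT assay, with a stated time of 48 h (on this read-out higher numbers stand for weaker inhibition of growth and lower numbers for stronger inhibition of growth), compound 3 (`Cc1ccc(OCCCN(Cc2ccc(C(=O)NO)cc2)c2ncc(-c3ccc(C)cc3)s2)cc1`) gives 12600 nM. This lies within the scatter of compound 1 (`CCCCCN(Cc1ccc(C(=O)NO)cc1)c1ncc(-c2ccc(C)cc2)s1`), which gives 23300 nM. Compound 2 (`Cc1ccc(-c2cnc(N(Cc3ccc(C(=O)NO)cc3)CC(C)C)s2)cc1`) gives 5900 nM, and the data show a 2.1-fold higher number from compound 2 to compound 3 (0.33 log units; beyond the scatter).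

The unmeasured compound 4 (`CCCCCCN(Cc1ccc(C(=O)NO)cc1)c1ncc(-c2ccc(C)cc2)s1`) carries propyl in place of 4-methylphenoxy on a saturated chain carbon, three bonds along the chain from a nitrogen on an aromatic ring.

The closest evidence is the exchange at that same place, 4-methylphenoxy in place of ethyl, which gave a 1.8-fold lower number from compound 1 to compound 3 (0.27 log units; within the scatter). The larger 3.9-fold lower number from compound 1 to compound 2 (0.60 log units; beyond the scatter), with isopropyl in place of butyl, arose at a different place on the chain and bears less directly. Read in reverse, the exchange at the same place points to a small step in this assay, perhaps towards a higher number and not clearly beyond the scatter. The expected step is a 1.4-fold higher number from compound 3 to compound 4 (0.15 log units; within the scatter). For compound 4 the estimated value is 18000 nM, with an expected range from 8000 nM to 40000 nM.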

Compound 4, concentration for 50% growth inhibition: 4850 nM
For compound 4 the middle estimate is 3.7-fold (0.57 log units) above the measured one, outside the stated range (below it).
By their numbers in this assay, from the lowest: compounds 4 and 2 (each within the scatter of the next); then compounds 3 and 1 (each within the scatter of the next).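

In this assay the step of a 2.6-fold lower number from compound 3 to compound 4 (0.41 log units; beyond the scatter) with propyl in place of 4-methylphenoxy shows that this position does not depend on the 4-methylphenoxy group, since the hexyl chain of compound 4 lies on the lower side of it. Among the compounds shown here, a single added methyl at the chain end, five bonds along the chain from a nitrogen on an aromatic ring, gives a 4.8-fold lower number from compound 1 to compound 4 (0.68 log units; beyond the scatter) and is beyond the scatter, a sensitivity to chain length that the earlier compounds did not show. Pentyl in place of isopropyl gives only a 1.2-fold lower number from compound 2 to compound 4 (0.09 log units; within the scatter) and is within the scatter, so the chains of compound 2 and compound 4 cannot be told apart here.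

From the compounds shown here alone, whether a longer chain, or an amine or a carboxylic acid at the chain end, would lower or raise the number remains open. Nothing available explains these differences.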